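The compounds below may be only part of what the source reports. "The series", "measured", "known", "first", "only" and "open" are said of these compounds alone.

Measured compounds:
compound 1 `CCc1cccc(NC(=O)CSc2nc(Nc3ccccc3)c3ccccc3n2)c1` — 12000 nM
compound 2 `C=CC(=O)Nc1cccc(NC(=O)CSc2nc(Nc3ccccc3)c3ccccc3n2)c1` — 8120 nM
compound 3 `O=C(CSc1nc(Nc2ccccc2)c2ccccc2n1)Nc1ccc([N+](=O)[O-])cc1` — 13000 nM

All three numbers come from a functional assay on NCI-H1975 cells (Homo sapiens) for inhibition, read by MTT assay, with a stated time of 72 h; a lower number here means a stronger inhibitor, a higher number a weaker inhibitor. Compound 2 gives the lowest of the three numbers, but neither neighbour is separated from it: the step of a 1.5-fold lower number from compound 1 to compound 2 (0.17 log units; within the scatter) and the step of a 1.6-fold higher number from compound 2 to compound 3 (0.20 log units; within the scatter) both sit inside the scatter, as does a 1.1-fold higher number from compound 1 to compound 3 (0.03 log units; within the scatter). The three measured compounds differ only at the amide-type nitrogen side of the shared core, and none of those changes moves the number.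

Compound 4 `C=CC(=O)Nc1cccc(NC(=O)CSc2nc(Nc3cc(OC)c(OC)c(OC)c3)c3ccccc3n2)c1` is the next compound. Relative to compound 2 the change is 3,4,5-trimethoxyphenyl in place of phenyl on a nitrogen on an aromatic ring. Going by the values given here, no measured step touches this nitrogen on the aromatic ring; the three measured steps bear on the other end of the molecule and so give no direct guide. Since the measured changes left the number flat, the expectation for compound 4 is a step of about a 1.0-fold lower number from compound 2 to compound 4 (0.01 log units; within the scatter), no clear direction beyond the scatter. Compound 4 is therefore estimated at 8000 nM, with a range from 3000 nM to 25000 nM.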

Compound 4, half-maximal inhibitory concentration: > 50000 nM
Compound 4: a limit, no number; the forecaster's own chance of this, stated with the estimate: 10%; at least 6.2-fold (0.79 log units) between middle value and limit.
By their numbers in this assay, from the lowest: compounds 2, 1 and 3 (each within the scatter of the next). At a limit, above all of these: compound 4.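

Going by these compounds alone, the amide-type nitrogen side of the shared core gave only steps within the scatter, whereas the nitrogen on an aromatic ring gives the first step beyond it: an at least 6.1-fold higher number from compound 2 to compound 4 (0.78 log units; beyond the scatter). The number in this assay therefore depends on the group at this nitrogen, and 3,4,5-trimethoxyphenyl in place of phenyl goes in the weaker direction with the rest of compound 2 unchanged. The value of compound 4 is a limit of the assay, not a number: the limit of > 50000 nM in this assay, at which 1 of the 4 values shown sits.

A single change cannot show whether one methoxy group or a chlorine on the phenyl would follow phenyl or 3,4,5-trimethoxyphenyl. Also open, from the compounds shown here alone, are whether any group at this nitrogen gives a lower number than compound 2, and whether the same change behaves alike with the ethyl of compound 1 at the other end.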